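Methylation of the fused-ring nitrogen in compound 4

The compounds below may be only part of what the source reports. "The series", "measured", "known", "first", "only" and "open" are said of these compounds alone.

Compound 3 `O=C(Nc1ccc(Oc2ccnc3[nH]ccc23)c(F)c1)c1cc2cccnc2n(-c2ccc(Br)cc2F)c1=O` gives 820 nM in a functional assay on HT-29 cells (Homo sapiens) for antiproliferative activity, read by MTT assay, with a stated time of 72 h (a lower number here means a stronger inhibitor, a higher number a weaker inhibitor), the highest of the three numbers in the series. Compound 1 `O=C(Nc1ccc(Oc2ccnc3[nH]ccc23)c(F)c1)c1cc2cccnc2n(-c2ccc(F)cc2)c1=O` gives 36 nM and compound 2 `O=C(Nc1ccc(Oc2ccnc3[nH]ccc23)c(F)c1)c1cc2cccnc2n(-c2ccc(F)c(Cl)c2)c1=O` gives 310 nM; the steps of a 23-fold higher number from compound 1 to compound 3 (1.36 log units; beyond the scatter) and a 2.6-fold higher number from compound 2 to compound 3 (0.42 log units; beyond the scatter) both run upward toward compound 3. Compound 4 `Cn1ccc2c(Oc3ccc(NC(=O)c4cc5cccnc5n(-c5ccc(Br)cc5F)c4=O)cc3F)ccnc21` differs from compound 3 by methyl in place of hydrogen on an aromatic nitrogen. Among the measured compounds shown here, every measured step concerns the aryl group carried on an aromatic nitrogen of the core; none concerns the five-membered ring, so no measured step bears on this change and the expectation rests on the value of compound 3 alone. A modest upward step is expected, a 1.8-fold higher number from compound 3 to compound 4 (0.26 log units; within the scatter), with wide uncertainty. Compound 4 is therefore estimated at 1500 nM, within 400 nM to 6000 nM.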

Compound 4, half-maximal inhibitory concentration: 3290 nM
Beside the measured number, compound 4's estimate is 2.2-fold (0.34 log units) below it, and the stated range covers the measured number.
By their numbers in this assay, from the lowest: compound 1; then compound 2; then compound 3; then compound 4.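

Methyl in place of hydrogen on the aromatic nitrogen of the five-membered ring gives a 4.0-fold higher number from compound 3 to compound 4 (0.60 log units; beyond the scatter) in this assay. Among the compounds shown here, this is the first measured change away from the aryl group, and it shows that the number also responds at this second position, on the background of the 4-bromo-2-fluorophenyl group. Nothing at hand accounts for the size of this step.

As far as these compounds go, whether an ethyl group or a longer chain ending in an amine on this nitrogen would move the number further stays open. So does whether methyl gives a similar step with the 4-fluorophenyl group of compound 1.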